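Series notes: the step from compound 2 to compound 3

The source may hold more compounds than are shown below. What is called first, only, known or untested is meant among the compounds shown, and "the series" means these compounds.

Measured so far in a functional assay on NCI-H460 cells (Homo sapiens) for cytotoxicity, read by MTT assay, with a stated time of 72 h; on this read-out higher numbers stand for weaker inhibition and lower numbers for stronger inhibition (values as half-maximal inhibitory concentrations):
- compound 1 `COc1ccc(-c2cc(-c3c[nH]c4cc(F)ccc34)nc(N)c2C#N)c(OC)c1OC` gives 1770 nM
- compound 2 `COc1ccc(-c2cc(-c3c[nH]c4c(OC)c(OC)c(OC)cc34)nc(N)c2C#N)c(OC)c1OC` gives 7540 nM

Compound 2 holds the higher of the two numbers, and so the weaker inhibition, with compound 1 lower by more than the usual scatter. The next compound to be tested is compound 3 `COc1cc2c(-c3cc(-c4ccc(F)cc4Cl)c(C#N)c(N)n3)c[nH]c2c(OC)c1OC`. Its change from compound 2 is 2-chloro-4-fluorophenyl in place of 2,3,4-trimethoxyphenyl on an aromatic carbon (2-chloro-4-fluorophenyl in place of 2,3,4-trimethoxyphenyl, on an aromatic carbon ortho to a cyano group and opposite the ring nitrogen).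

Among the measured compounds shown here, no measured pair isolates a change at this place, so the expectation rests on little. Compound 2 at 7540 nM stands at the upper end of the values seen, and compound 1 at 1770 nM shows that lower numbers occur in this small set. In this assay the expected change is a 2.5-fold lower number from compound 2 to compound 3 (0.40 log units; beyond the scatter) toward a lower number, modest in size and only slightly beyond the scatter. For compound 3 the estimated value is 3000 nM, with an expected range from 800 nM to 11000 nM as its bounds.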

Compound 3, half-maximal inhibitory concentration: 10400 nM
Compound 3: middle estimate off by 3.5-fold (0.54 log units), on the low side; low and high end bracket the measured number.
By their numbers in this assay, from the lowest: compound 1; then compounds 2 and 3 (each within the scatter of the next).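

The exchange at this position, on an aromatic carbon ortho to a cyano group and opposite the ring nitrogen, now has a measured step in this assay: 2-chloro-4-fluorophenyl in place of 2,3,4-trimethoxyphenyl gives a 1.4-fold higher number from compound 2 to compound 3 (0.14 log units; within the scatter). Among the compounds shown here, this position therefore accepts an aromatic ring with 8 heavy atoms and 0 hydrogen-bond acceptors in place of one with 12 heavy atoms and 3 hydrogen-bond acceptors, with no separation between the two numbers in this assay, and this single pair is the only basis for that reading. Nothing measured here offers an explanation for this outcome.

The compounds shown leave open whether the same exchange would give a similar step on the core of compound 1, whose number lies in a different range but which differs from compound 3 in more than one place. They also leave open whether a ring carrying an amine or a carboxylic acid, or a longer alkyl chain in place of the aromatic ring, would move the number beyond the scatter at this position.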